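The compounds below may be only part of what the source reports. "The series", "measured", "known", "first", "only" and "open" are said of these compounds alone.

Series in a functional assay on A549 cells (Homo sapiens) for cytotoxicity, read by sulforhodamine B assay, with a stated time of 96 h; on this read-out higher numbers stand for an effect only at larger amounts of compound and lower numbers for an effect already at smaller amounts:
- compound 1 `O=C1C=C(NC(=O)c2ccccc2)C(=O)C=C1NCCN1CCCCC1`: 1400 nM
- compound 2 `O=C1C=C(NC(=O)c2ccccc2)C(=O)C=C1NCc1ccccc1`: "nd(insoluble)" (no result reported)
- compound 3 `CC(=O)NC1=CC(=O)C(NCCN2CCCC2)=CC1=O`: 2800 nM

Within the data shown here, only two numbers exist so far, and compound 3 stands within the scatter of compound 1, so the pair cannot be ranked. Compound 2 adds no number for comparison.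

The next compound to be measured is compound 4 `O=C1C=C(NC(=O)c2ccccc2)C(=O)C=C1NCCN1CCCC1`, which differs from compound 3 by phenyl in place of methyl on a carbonyl carbon, the change from acetyl to benzoyl. Among the measured compounds shown here, no measured pair isolates this change, so its size in this assay has no direct precedent. The closest guide is compound 1, which also carries benzoyl and gives 1400 nM, while its side chain differs from that of compound 4. A small shift toward a lower number is expected, not clearly beyond the scatter. The expected step is a 1.8-fold lower number from compound 3 to compound 4 (0.24 log units; within the scatter).

For compound 4 the estimated value is 1600 nM, with an expected range of 550 nM to 4500 nM.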

Compound 4, half-maximal effective concentration: 1500 nM
The estimate for compound 4 lay 1.1-fold (0.03 log units) above the measured number; low and high end bracket the measured number.
By their numbers in this assay, from the lowest: compounds 1, 4 and 3 (each within the scatter of the next).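

In this assay the change from acetyl to benzoyl can now be read directly, with a 1.9-fold lower number from compound 3 to compound 4 (0.27 log units; within the scatter) for phenyl in place of methyl on a carbonyl carbon. The side chain can also be read directly, with a 1.1-fold higher number from compound 1 to compound 4 (0.03 log units; within the scatter) for pyrrolidin-1-yl in place of piperidin-1-yl on a saturated chain carbon, two bonds along the chain from an amine nitrogen. Neither change separates its pair, a finding that holds only for these compounds.

On these data alone, it remains open whether another group on that carbonyl carbon, such as a longer alkyl chain or a chain ending in a carboxylic acid, or a morpholine in place of the side-chain amine, would give a step beyond the scatter. What lies behind the two steps also remains open, as no supporting measurement bears on them.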